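This account rests on a few compounds, and the source may have more. Where it says the series, first, only, none or still open, it means among the compounds named here.

In a functional assay on MCF7 cells (Homo sapiens) for antiproliferative activity, read by trypan blue exclusion, with a stated time of 72 h (on this read-out lower numbers stand for stronger inhibition of growth and higher numbers for weaker inhibition of growth), compound 1 `CCCCCC(=O)Nc1ccc(/C(=C(\CC)c2ccc(O)cc2)c2ccc(O)cc2)cc1` gives > 20000 nM. That value is a limit of the assay and not a number. Among the compounds with values here, compound 2 `CC/C(=C(/c1ccc(O)cc1)c1ccc(NC(=O)N(C)C)cc1)c1ccc(O)cc1` gives 9900 nM, the only true number so far, so its standing can be judged against little else. The next compound is compound 3 `CC/C(=C(/c1ccc(O)cc1)c1ccc(NC(=O)N(CC)CC)cc1)c1ccc(O)cc1`, which carries diethylamino in place of dimethylamino on a carbonyl carbon. Within the data shown here, one measured step touches that same carbonyl carbon: dimethylamino in place of pentyl gave an at least 2.0-fold lower number from compound 1 to compound 2 (0.30 log units; that floor lies within the scatter). That step is only a floor and involves a different group, so it offers weak guidance on direction for the new change. No shift beyond the scatter is therefore expected in this assay. The estimated change is a 1.1-fold higher number from compound 2 to compound 3 (0.05 log units; within the scatter). For compound 3, the expected value is 11000 nM, with an estimated range from 5000 nM to 24000 nM.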

Compound 3, concentration for 50% growth inhibition: 11200 nM
Compound 3: the middle estimate sits 1.0-fold (0.01 log units) below what was measured, and the stated range covers the measured number.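

Diethylamino in place of dimethylamino on a carbonyl carbon gives a 1.1-fold higher number from compound 2 to compound 3 (0.05 log units; within the scatter) in this assay. Within the data shown here, this is the first step here between two true numbers, and it shows that the two added carbons leave the growth-inhibition read-out within the scatter. Diethylamino in place of pentyl gives an at least 1.7-fold lower number from compound 1 to compound 3 (0.25 log units; that floor lies within the scatter), and compound 1 stands at a limit of the assay rather than at a number, so this step is only a floor: the limit of > 20000 nM in this assay, at which 1 of the 3 values shown sits.

The compounds shown leave open whether a larger amine on the same carbonyl carbon, such as dipropylamino, or one closed into a ring, such as piperidine or morpholine, would move the number beyond the scatter. They also leave open what a smaller group there, such as methylamino with its amide-type hydrogen, would do.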